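Sulfonyl aryl swap in a bradykinin receptor antagonist series

This account rests on a few compounds, and the source may have more. Where it says the series, first, only, none or still open, it means among the compounds named here.

Measured compounds:
Compound 1 `CCCCOc1ccc(S(=O)(=O)N2CCCC[C@H]2CC(=O)N[C@@H]2CCCc3cc(CNC(C)(C)C)ccc32)cc1` — 1200 nM
Compound 2 `CC(C)(C)NCc1ccc2c(c1)CCC[C@H]2NC(=O)C[C@@H]1CCCCN1S(=O)(=O)c1ccc(Cl)cc1` — 560 nM

Both numbers come from an assay on isolated protein for inhibition of B1 bradykinin receptor (Homo sapiens); on this read-out lower numbers stand for stronger inhibition and higher numbers for weaker inhibition. Compound 1 stands highest of the two; its nearest neighbour is compound 2, reached by a 2.1-fold lower number from compound 1 to compound 2 (0.33 log units; beyond the scatter), a chloro in place of butoxy on an aromatic carbon.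

Compound 3 `Cc1ccc(S(=O)(=O)N2CCCC[C@H]2CC(=O)N[C@@H]2CCCc3cc(CNC(C)(C)C)ccc32)cc1Cl` is not yet measured. It differs from compound 1 by 3-chloro-4-methylphenyl in place of 4-butoxyphenyl on a sulfonyl sulfur. Going by the values given here, the one measured step that bears on this is a 2.1-fold lower number from compound 1 to compound 2 (0.33 log units; beyond the scatter), which likewise removes the butoxy and brings a chlorine onto the aryl on the sulfonyl sulfur. Compound 3 also carries a methyl on that ring, for which no comparison exists, so the methyl is left out of the reckoning. A step of similar size and in the same direction, a lower number in this assay, is therefore expected. For compound 3 the estimated value is 500 nM, with a range of 200 nM to 1500 nM, which means an expected step of a 2.4-fold lower number from compound 1 to compound 3 (0.38 log units; beyond the scatter).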

Compound 3, half-maximal inhibitory concentration: 15 nM
Estimate against measurement, compound 3: 33-fold (1.52 log units) above; the whole stated range lies above it.
By their numbers in this assay, from the lowest: compound 3; then compound 2; then compound 1.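

On the aryl on the sulfonyl sulfur, 3-chloro-4-methylphenyl in place of 4-chlorophenyl gives a 37-fold lower number from compound 2 to compound 3 (1.57 log units; beyond the scatter) in this assay, so losing the butoxy and bringing in a chlorine does not by itself account for the lowest number in the set. In the same assay, the change from 4-butoxyphenyl gives an 80-fold lower number from compound 1 to compound 3 (1.90 log units; beyond the scatter), far larger than the modest step between compound 1 and compound 2, so this position tolerates much wider swings than those two compounds showed. No measurement at hand explains the size of these steps.

Compound 3 differs from compound 2 in both the placement of its chlorine and its added methyl, so the compounds shown do not separate the share of each. From the compounds shown here alone, whether a phenyl carrying only that methyl or only that chlorine would hold the low number stays open, as does the outcome with an ethyl or trifluoromethyl in place of the methyl.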